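Adding a tert-butyl group to the benzyl arm of compound 2

The source may hold more compounds than are shown below. What is called first, only, known or untested is meant among the compounds shown, and "the series" means these compounds.

Of the compounds shown here, two sharing one core have been measured in a functional assay on A549 cells (Homo sapiens) for cytotoxicity, read by MTT assay, with a stated time of 48 h; on this read-out higher numbers stand for higher solubility and lower numbers for lower solubility. Compound 1 `O=C(N/N=C/c1ccccc1O)c1cc(-c2ccccc2)nn1Cc1ccc(Cl)nc1` gives 45000 nM. Compound 2 `O=C(N/N=C/c1ccccc1O)c1cc(-c2ccccc2)nn1Cc1ccccc1` gives 44000 nM. Within the data shown here, the one measured step, a 1.0-fold lower number from compound 1 to compound 2 (0.01 log units; within the scatter), lies within the scatter, so compound 2 stands on the same level as compound 1 in this assay and no order between the two can be claimed.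

Compound 3 `CC(C)(C)c1ccc(Cn2nc(-c3ccccc3)cc2C(=O)N/N=C/c2ccccc2O)cc1` is the next member, not yet measured. It differs from compound 2 by tert-butyl in place of hydrogen on an aromatic carbon. Among the measured compounds shown here, the only measured step concerned a swap of one ring for another on the chain carbon bound to the aromatic nitrogen; it did not touch the position changed here, so it bears on the present change only loosely. That step was within the scatter, and nothing else in the series speaks for a shift in either direction. The expectation for compound 3 is therefore a step of about no change at the digits printed from compound 2 to compound 3 (within the scatter), no larger than the scatter. Compound 3 is estimated at 44000 nM, with a range from 20000 nM to 95000 nM.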

Compound 3, solubility: 47000 nM
Compound 3: middle estimate off by 1.1-fold (0.03 log units), on the low side; low and high end bracket the measured number.
By their numbers in this assay, from the lowest: compounds 2, 1 and 3 (each within the scatter of the next).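

In this assay, tert-butyl, a group of 4 carbon atoms with no ring, on an aromatic carbon of the benzyl arm gives a 1.1-fold higher number from compound 2 to compound 3 (0.03 log units; within the scatter) and so leaves the number within the scatter, which shows that this position, untouched by the earlier pair, can carry a group of this size with no readable shift. Comparing the whole arm gives the same picture, with 4-(tert-butyl)phenyl in place of 6-chloropyridin-3-yl giving a 1.0-fold higher number from compound 1 to compound 3 (0.02 log units; within the scatter) and no order among the three arms that can be claimed in this assay. No supporting measurement is available to account for this flat result.

The compounds shown leave open whether a group of a different kind on the same aromatic carbon, such as an amine or a carboxylic acid, would stay on this level as tert-butyl does. They also leave open what a change to the shared core would do, as all three compounds differ only in the arm on the saturated chain carbon.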